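An ethyl to tert-butyl swap at an assay limit

The compounds below may be only part of what the source reports. "The series", "measured", "known", "first", "only" and "open" are said of these compounds alone.

In a functional assay on HCT-116 cells (Homo sapiens) for antiproliferative activity, read by MTT assay, with a stated time of 72 h (a higher number here means a weaker inhibitor, a lower number a stronger inhibitor), compound 1 `C=CC(=O)Nc1ccc(Cl)c(S(=O)(=O)N(C)C)c1` gives 24600 nM and compound 2 `C=CC(=O)Nc1nc(-c2ccccc2)cs1` gives 18600 nM. Compound 3 `C=CC(=O)N(CC(=O)OCC)c1nc(-c2ccccc2)cs1` reads > 30000 nM, which is a limit and not a number. Compound 3 therefore stands at the limit of > 30000 nM in this assay, at which 1 of the 3 values shown sits.

Compound 4 `C=CC(=O)N(CC(=O)OC(C)(C)C)c1nc(-c2ccccc2)cs1` carries tert-butyl in place of ethyl on an oxygen next to a carbonyl group, so that (ethoxycarbonyl)methyl becomes (tert-butoxycarbonyl)methyl. Among the compounds with values here, no measured step makes this exchange. The nearest one introduces (ethoxycarbonyl)methyl in place of hydrogen on an amide-type nitrogen, and it amounts to an at least 1.6-fold higher number from compound 2 to compound 3 (0.20 log units; that floor lies within the scatter). That step gives no ground for a shift in either direction, so no change beyond the scatter is expected in this assay. The estimated step is a number no higher from compound 3 to compound 4 (the limit leaves the size open). For compound 4 the expected value is 30000 nM, with an estimated range from 15000 nM to 60000 nM.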

Compound 4, half-maximal inhibitory concentration: 20900 nM
For compound 4 the middle estimate is 1.4-fold (0.16 log units) above the measured one, and the stated range covers the measured number.
By their numbers in this assay, from the lowest: compounds 2, 4 and 1 (each within the scatter of the next). At a limit, above all of these: compound 3.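

In this assay a substituent on the amide-type nitrogen now has an actual number rather than a limit: (tert-butoxycarbonyl)methyl in place of hydrogen gives a 1.1-fold higher number from compound 2 to compound 4 (0.05 log units; within the scatter). Going by these compounds, the exchange of ethyl for tert-butyl on the oxygen next to a carbonyl group gives an at least 1.4-fold lower number from compound 3 to compound 4 (0.15 log units; that floor lies within the scatter), so its true size stays open and nothing printed places it beyond the scatter. Compound 3 remains a limit and not a number: the limit of > 30000 nM in this assay, at which 1 of the 4 values shown sits.

The compounds shown leave open whether a carboxylic acid, an amine or a longer chain in place of (tert-butoxycarbonyl)methyl on the amide-type nitrogen would read differently in this assay. They also leave open whether such a substituent would read the same on the core of compound 1, which carries none.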